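A methylphenyl in place of a dichlorophenyl on the ring amine

The source may hold more compounds than are shown below. What is called first, only, known or untested is meant among the compounds shown, and "the series" means these compounds.

Compound 1, `CC(C)Cc1ccc(C(C)C(=O)NCc2ccc(C(F)(F)F)cc2)cc1`, gives 51000 nM in an assay on brain for inhibition of Fatty-acid amide hydrolase 1 (Rattus norvegicus), read by scintillation counting, with a stated time of 10 min; a higher number here means a weaker inhibitor, a lower number a stronger inhibitor. Compound 2, `CC(C)Cc1ccc(C(C)C(=O)NCc2ccc(Cl)c(Cl)c2)cc1`, gives 36000 nM in this assay. Compound 3, `CC(C)Cc1ccc(C(C)C(=O)N2CCN(c3ccc(Cl)c(Cl)c3)CC2)cc1`, gives 16000 nM in this assay.

All three compounds share the same core and differ only at the amide end. Compound 3 has the lowest number of the three, which means it is the strongest inhibitor here: compound 2 sits beyond the scatter above it, and compound 1 further above still. Compound 4, `Cc1cccc(N2CCN(C(=O)C(C)c3ccc(CC(C)C)cc3)CC2)c1`, is not yet measured. It differs from compound 3 in one place: 3-methylphenyl in place of 3,4-dichlorophenyl on an amine nitrogen in a ring. Within the data shown here, no measured pair shows this exact change, so its direction is not known from these data; the two halogen-bearing aryl groups in compounds 1 and 2 give numbers that lie close to each other. Among the measured compounds shown here, a modest weakening is expected for a 1.6-fold higher number from compound 3 to compound 4 (0.19 log units; within the scatter), with a wide margin because the change has no measured precedent. For compound 4 the estimated value in this assay is 25000 nM, within a range from 8000 nM to 80000 nM.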

Compound 4, half-maximal inhibitory concentration: 16000 nM
Compound 4: the middle estimate sits 1.6-fold (0.19 log units) above what was measured; measured number inside the range.
By their numbers in this assay, from the lowest: compounds 3 and 4 (each within the scatter of the next); then compounds 2 and 1 (each within the scatter of the next).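

In this assay, among these compounds, the exchange of 3,4-dichlorophenyl for 3-methylphenyl on an amine nitrogen in a ring gives no change at the digits printed from compound 3 to compound 4 (within the scatter) and this is the first direct reading of a change at this position. The aryl group here can lose both chlorine atoms and gain a methyl group with no readable shift in the number, so for this pair the chlorine atoms are not required to keep the inhibition seen with compound 3. Nothing shown here offers any measurement that could explain this result.

This single step swaps out both chlorine atoms and brings in the methyl group at once, so a 3-chlorophenyl or an unsubstituted phenyl would be needed to separate those parts. From the compounds shown here alone, whether this position stays as undemanding for a carboxylic acid or an amine on the aryl ring remains open.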